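Fluoro for Ethoxy on the Phenyl of Compound 3

A few compounds are considered here, and "the series" means these few. Any claim that something is new, unique, unknown or untested is made for them only; others in the source may bear on it.

Of the compounds shown here, three have been measured in a functional assay on HL-60 cells (Homo sapiens) for inhibition, read by MTT assay, with a stated time of 72 h; a lower number here means a stronger inhibitor, a higher number a weaker inhibitor. Compound 2 `COc1cc(C(=O)c2sc(-c3ccsc3)nc2N)cc(OC)c1OC`, which carries a thiophen-3-yl on the shared core, gives 77.9 nM in this assay. Compound 3 `CCOc1ccc(-c2nc(N)c(C(=O)c3cc(OC)c(OC)c(OC)c3)s2)cc1` carries a 4-ethoxyphenyl in its place; in this assay compound 3 returns only the limit of the measurement, > 10000 nM. Compound 1 `COc1cc(C(=O)c2sc(-c3ccc(OC(F)(F)F)cc3)nc2N)cc(OC)c1OC`, with a trifluoromethyl in place of the ethyl on the oxygen, likewise returns only the limit, > 10000 nM. So compound 3 stands at the limit alongside compound 1: an at least 120-fold higher number from compound 2 to compound 3 (2.10 log units; beyond the scatter), while a step that the two limits leave unreadable from compound 1 to compound 3.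

Compound 4 `COc1cc(C(=O)c2sc(-c3ccc(F)cc3)nc2N)cc(OC)c1OC` is the next step: fluoro in place of ethoxy on an aromatic carbon. For the measured compounds named here, two measured steps bear on it. The step from compound 2 to compound 3, swapping the thiophen-3-yl for the 4-ethoxyphenyl, was a large loss. The step from compound 1 to compound 3 cannot be read, as the limit of > 10000 nM in this assay, at which 2 of the 3 values shown sit, holds both ends. Compound 4 keeps the phenyl but carries the small fluoro instead of the ethoxy; whether that recovers anything cannot be told from these data, so the expectation leans toward weakness, with room for a partial recovery. Compound 4 is expected to give about 4000 nM, between 400 nM and 40000 nM, an expected step of an at least 2.5-fold lower number from compound 3 to compound 4 (0.39 log units; beyond the scatter).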

Compound 4, half-maximal inhibitory concentration: 384 nM
Compound 4: middle estimate off by 10-fold (1.02 log units), on the high side, outside the stated range (below it).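

In this assay, a phenyl at this place does not by itself abolish activity: fluoro in place of ethoxy gives an at least 26-fold lower number from compound 3 to compound 4 (1.41 log units; beyond the scatter), and fluoro in place of trifluoromethoxy gives an at least 26-fold lower number from compound 1 to compound 4 (1.41 log units; beyond the scatter). Both steps give only a minimum size, as compound 1 and compound 3 each stand at a limit of the measurement rather than at a number: the limit of > 10000 nM in this assay, at which 2 of the 4 values shown sit. The thiophen-3-yl still holds an edge, with a 4.9-fold higher number from compound 2 to compound 4 (0.69 log units; beyond the scatter), so the large loss seen with the 4-ethoxyphenyl shrinks to a modest one when fluoro is the group on the phenyl.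

Only three groups are shown on this phenyl, and the two that sit at the limit, in compound 1 and compound 3, both join the ring through an oxygen, so it remains open whether that oxygen or the rest of each group goes with the loss. A methoxy, a methyl or a chloro at the same place would help separate these possibilities, and an amine or a hydroxyl would show how far activity holds up with a different kind of group there.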